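A few compounds are considered here, and "the series" means these few. Any claim that something is new, unique, unknown or untested is made for them only; others in the source may bear on it.

Measured compounds:
- compound 1, `c1ccc(Cn2cncc2-c2cc3ccccc3[nH]2)cc1`, 10800 nM
- compound 2, `Brc1ccc2[nH]c(-c3cncn3Cc3ccc(-c4ccccc4)cc3)cc2c1`, 3090 nM
- compound 3, `N#Cc1ccc(Cn2cncc2-c2cc3cc(Br)ccc3[nH]2)cc1`, 6920 nM

In an assay on HEK293 cells for inhibition of Indoleamine 2,3-dioxygenase 1 (Homo sapiens), with a stated time of 30 min (on this read-out higher numbers stand for an effect only at larger amounts of compound and lower numbers for an effect already at smaller amounts), compound 3 stands second highest of the three numbers. Its nearest neighbour is compound 1, whose value is within the scatter of it; its furthest is compound 2, and the step of a 2.2-fold higher number from compound 2 to compound 3 (0.35 log units; beyond the scatter) is modest but beyond the scatter.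

Compound 4, `Oc1cccc(Cn2cncc2-c2cc3cc(Br)ccc3[nH]2)c1`, is not yet measured. It differs from compound 3 by 3-hydroxyphenyl in place of 4-cyanophenyl on a saturated chain carbon bound to an aromatic nitrogen. Among the measured compounds shown here, the only measured step that bears on this change is the one from compound 2 to compound 3, which also alters the group on that same side chain: a 2.2-fold higher number from compound 2 to compound 3 (0.35 log units; beyond the scatter). That step shows the side-chain group matters to a modest degree, but it does not involve a hydroxyphenyl, so no direction can be read from it. The expected step is therefore a 1.1-fold lower number from compound 3 to compound 4 (0.03 log units; within the scatter), placed near no change. Compound 4 is estimated at 6500 nM in this assay, with a range from 2500 nM to 16000 nM.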

Compound 4, half-maximal effective concentration: 9970 nM
For compound 4 the middle estimate is 1.5-fold (0.19 log units) below the measured one; measured number inside the range.
By their numbers in this assay, from the lowest: compound 2; then compounds 3, 4 and 1 (each within the scatter of the next).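

In this assay, 3-hydroxyphenyl in place of 4-cyanophenyl on a saturated chain carbon bound to an aromatic nitrogen gives a 1.4-fold higher number from compound 3 to compound 4 (0.16 log units; within the scatter), so at this position a ring bearing a hydroxyl and a ring bearing a nitrile cannot be told apart. The earlier step of a 2.2-fold higher number from compound 2 to compound 3 (0.35 log units; beyond the scatter) showed that the group on this side chain can shift the number, and the new step shows that not every exchange there does. No measurement at hand accounts for this result.

The step exchanges the group and its place on the ring together, so the two contributions cannot be separated. Going by these compounds, how an amine or a carboxylic acid on this ring would read remains open, as does the effect of a longer chain between the ring and the aromatic nitrogen.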